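The source may report more compounds than this note shows. Statements on the series, on what has been measured and on what is new or still open speak of the compounds shown alone.

Of the compounds shown here, three with a shared core have been measured so far in an ADME assay (liver) for metabolic stability, with Liver microsome (Rattus norvegicus) as the target, using microsomes and NADPH, with a stated time of 30 min, tested at 1 uM (on this read-out lower numbers stand for slow clearance and higher numbers for fast clearance), as the read-out. Compound 1 (`NC(=O)c1cccc(-c2cc(C(O)(C(F)(F)F)C(F)(F)F)cnc2N2CCN(S(=O)(=O)c3ccc(N)nc3)CC2)c1`) gives 63 mL.min-1.g-1 and compound 2 (`Nc1ccc(S(=O)(=O)N2CCN(c3ncc(C(O)(C(F)(F)F)C(F)(F)F)cc3-c3cncc(F)c3)CC2)cn1`) gives 19 mL.min-1.g-1 while compound 3 (`COc1ccc(-c2cc(C(O)(C(F)(F)F)C(F)(F)F)cnc2N2CCN(S(=O)(=O)c3ccc(N)nc3)CC2)cn1`) gives 265 mL.min-1.g-1 as the highest of the three numbers. Compound 3 is therefore the fastest cleared of this small set. Compound 4 (`Nc1ccc(S(=O)(=O)N2CCN(c3ncc(C(O)(C(F)(F)F)C(F)(F)F)cc3-c3ccc4c(c3)CC(=O)N4)CC2)cn1`) is still unmeasured and differs from compound 3 at a single place (a group of 10 heavy atoms (8 carbon, 1 nitrogen, 1 oxygen; one five-membered non-aromatic ring with 1 hetero atom, one six-membered aromatic ring of carbon only) in place of a group of 8 heavy atoms (6 carbon, 1 nitrogen, 1 oxygen; one six-membered aromatic ring with 1 hetero atom), on an aromatic carbon), where the 6-methoxypyridin-3-yl group leaves.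

Two measured steps at that same place bear on the change. Putting 6-methoxypyridin-3-yl in place of 3-carbamoylphenyl gave a modest rise (a 4.2-fold higher number from compound 1 to compound 3 (0.62 log units; beyond the scatter)), and putting it in place of 5-fluoropyridin-3-yl gave a large one (a 14-fold higher number from compound 2 to compound 3 (1.14 log units; beyond the scatter)). In both steps, the group now leaving came with the higher number. The entering group resembles the 3-carbamoylphenyl of compound 1 (63 mL.min-1.g-1) in having a six-membered aromatic ring of carbon only, which makes that value the closest guide. In this assay a modest fall is expected, estimated as a 4.4-fold lower number from compound 3 to compound 4 (0.65 log units; beyond the scatter) and so beyond the scatter. Compound 4 is thus estimated at 60 mL.min-1.g-1 within an expected range of 20 mL.min-1.g-1 to 170 mL.min-1.g-1 overall.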

Compound 4, intrinsic clearance in microsomes: 119 mL.min-1.g-1
Compound 4: middle estimate off by 2.0-fold (0.30 log units), on the low side, within the range that was stated.
By their numbers in this assay, from the lowest: compound 2; then compounds 1 and 4 (each within the scatter of the next); then compound 3.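

In this assay, the group with one five-membered non-aromatic ring and one six-membered aromatic ring of carbon only gives a lower number than 6-methoxypyridin-3-yl (a 2.2-fold lower number from compound 3 to compound 4 (0.35 log units; beyond the scatter)) but a higher number than 5-fluoropyridin-3-yl (a 6.3-fold higher number from compound 2 to compound 4 (0.80 log units; beyond the scatter)), so this position gives values between those two groups. Set against 3-carbamoylphenyl, the only other group here with a six-membered aromatic ring of carbon only, the new group gives a step that lies within the scatter (a 1.9-fold higher number from compound 1 to compound 4 (0.28 log units; within the scatter)), so these two groups cannot be told apart on this read-out, although their rings and side parts are not the same. No measurement is at hand that explains why the values differ.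

The compounds shown leave open how a much smaller group on this same aromatic carbon, such as an amine or a carboxylic acid, would read, as every group here includes a six-membered aromatic ring. They also leave open which part of the change from 6-methoxypyridin-3-yl matters most, as the ring nitrogen and the methoxy group leave and the five-membered ring enters in one single step.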